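The compounds below may be only part of what the source reports. "The series", "measured", "known", "first", "only" and "open" are said of these compounds alone.

Among the measured compounds shown here, in a functional assay (HSMC cells, Homo sapiens) for antiproliferative activity, with a stated time of 72 h (on this read-out higher numbers stand for weaker inhibition and lower numbers for stronger inhibition), compound 1 (`COC(=O)[C@H](CCSC)NC(=O)c1ccc(C(=O)NC[C@H]2COc3ccccc3O2)cc1-c1ccccc1C`) gives 87000 nM, the lowest of the three numbers so far and thus the strongest inhibition measured in this small set. Compound 2 (`COC(=O)[C@H](CCSC)NC(=O)c1ccc(C(=O)NC[C@@H]2COc3ccccc3O2)cc1-c1ccccc1C`) gives 533000 nM and compound 3 (`COC(=O)[C@H](CCSC)NC(=O)c1ccc(C(=O)NC[C@H]2COc3ccccc3O2)cc1-c1ccccc1OC`) gives 252000 nM. The first comparison shows a 6.1-fold higher number from compound 1 to compound 2 (0.79 log units; beyond the scatter), and this gap can be traced to stereochemistry because of the fact that compounds 1 and 2 differ only in the configuration as drawn in this pair. The second shows a 2.9-fold higher number from compound 1 to compound 3 (0.46 log units; beyond the scatter), with methoxy in place of methyl on an aromatic carbon.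

Compound 4 (`COC(=O)[C@H](CC(C)C)NC(=O)c1ccc(C(=O)NC[C@H]2COc3ccccc3O2)cc1-c1ccccc1C`) changes a different part of compound 1: isopropyl in place of (methylsulfanyl)methyl on a saturated chain carbon, two bonds along the chain from an amide-type nitrogen and a carbonyl carbon. Here isopropyl takes the place of (methylsulfanyl)methyl on a saturated chain carbon. Neither measured step touches this place, so they bear on it only indirectly, as a rough guide to how far a single change has moved the numbers in this series. On that guide, a step no larger than those two is expected, and its direction cannot be firmly predicted. A slight rise is the modest expectation, since compound 1 already holds the lowest number at 87000 nM. The estimate is therefore a 1.3-fold higher number from compound 1 to compound 4 (0.10 log units; within the scatter). In this assay the expected value for compound 4 is 110000 nM, within an estimated range from 40000 nM to 280000 nM.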

Compound 4, half-maximal inhibitory concentration: 103000 nM
Estimate against measurement, compound 4: 1.1-fold (0.03 log units) above; measured number inside the range.
By their numbers in this assay, from the lowest: compounds 1 and 4 (each within the scatter of the next); then compound 3; then compound 2.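

In this assay, isopropyl in place of (methylsulfanyl)methyl gives a 1.2-fold higher number from compound 1 to compound 4 (0.07 log units; within the scatter), so this change, on a saturated chain carbon, two bonds along the chain from an amide-type nitrogen and a carbonyl carbon, leaves compound 1 and compound 4 indistinguishable, unlike the two earlier steps, which lie beyond the scatter. The two groups have the same count of heavy atoms and neither has a ring, but compound 4 has carbon where compound 1 has sulfur, so in this pair the sulfur atom and the hydrogen-bond acceptor counted for it can be exchanged with no difference that this read-out can resolve. No available evidence bears on why this step came out as it did.

As far as these compounds go, the two groups at this place are alike in size, so it remains open what an amine, a carboxylic acid, a phenyl ring or a longer chain would give there. From the compounds shown here alone, it also remains open whether isopropyl would behave the same way on the core of compound 2 or compound 3.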